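A few compounds are considered here, and "the series" means these few. Any claim that something is new, unique, unknown or untested is made for them only; others in the source may bear on it.

Compound 1 `O=C1Nc2ccc(Br)cc2/C1=N/NC(=S)Nc1ccc(Cl)cc1` and compound 2 `O=C1/C(=N\NC(=S)Nc2ccc(Cl)cc2)c2cc(Cl)ccc2N1Cc1ccc(F)cc1` share a core and have both been tested in a functional assay on CCRF-CEM cells (Homo sapiens), with a stated time of 72 h; on this read-out lower numbers stand for stronger inhibition and higher numbers for weaker inhibition. In this assay compound 1 gives 61000 nM. In this assay compound 2 gives 50000 nM. Compound 2 stands alongside compound 1: the two numbers lie within the usual scatter of repeated measurements, so neither can be called the stronger of the pair.

Compound 3 `O=C1/C(=N\NC(=S)Nc2ccc(Cl)cc2)c2cc(Br)ccc2N1Cc1ccc(F)cc1` has not yet been measured. It differs from compound 2 in one place: bromo in place of chloro on an aromatic carbon, a swap of one halogen for another on the same aromatic carbon. Going by the values given here, no pair of measured compounds shows what such a swap does here, so there is nothing to rest a direction on. The expectation is a step no larger than the scatter, in no clear direction. Compound 3 is therefore estimated at 50000 nM, with a range from 25000 nM to 100000 nM. The step this estimate implies, no change at the digits printed from compound 2 to compound 3 (within the scatter), is expected to lie within the scatter.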

Compound 3, half-maximal inhibitory concentration: 61000 nM
The estimate for compound 3 lay 1.2-fold (0.09 log units) below the measured number; the measured number falls inside the stated range.
By their numbers in this assay, from the lowest: compounds 2, 1 and 3 (each within the scatter of the next).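

In this assay, going by these compounds alone, bromo in place of chloro on an aromatic carbon gives a 1.2-fold higher number from compound 2 to compound 3 (0.09 log units; within the scatter), the first direct reading of a halogen swap at this position, and it shows no effect that can be told from the scatter. Compounds 1 and 2 differ in two places, whereas compounds 1 and 3 differ in one, so 4-fluorobenzyl in place of hydrogen on an amide-type nitrogen in a ring can now be read alone: it gives no change at the digits printed from compound 1 to compound 3 (within the scatter). Nothing available explains why either change leaves the number within the scatter.

Whether an amine or a carboxylic acid on that aromatic carbon would move the number remains open, since only two halogens are shown there. The same holds on the amide-type nitrogen, where only hydrogen and 4-fluorobenzyl appear, leaving open what a longer chain would do.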